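A Sulfur Substituent Swap, Carried to a Second Core

The compounds below may be only part of what the source reports. "The series", "measured", "known", "first", "only" and "open" are said of these compounds alone.

Compound 1 `O=C(N/N=C/c1c[nH]c2ccccc12)c1ccc(CSc2nc3ccccc3s2)cc1` and compound 2 `COc1cc(/C=N/NC(=O)c2ccc(CSc3nc4ccccc4s3)cc2)cc(OC)c1OC` carry the same group on the sulfur but differ in the larger remainder of the molecule; the difference between the two cores is not broken down here. In a functional assay on Huh-7 cells (Homo sapiens) for inhibition, read by MTT assay, with a stated time of 72 h (on this read-out lower numbers stand for stronger inhibition and higher numbers for weaker inhibition), compound 1 gives 7.74 ug/mL. Compound 2 reaches only a limit of this assay, > 80 ug/mL, and no number is known for it. Compound 3 `COc1cc(/C=N/NC(=O)c2ccc(CSc3nc(C)cc(C)n3)cc2)cc(OC)c1OC` keeps the core of compound 2 and carries a different group on the sulfur; the change is 4,6-dimethylpyrimidin-2-yl in place of 1,3-benzothiazol-2-yl on a sulfur. In this assay compound 3 gives 17.4 ug/mL, so the exchange brought an at least 4.5-fold lower number from compound 2 to compound 3 (0.66 log units; beyond the scatter). How large this step truly is cannot be fixed, because the starting point is the limit of > 80 ug/mL in this assay, at which 1 of the 3 values shown sits. Among the compounds with values here, of the two numbers known, compound 1 sits lowest, with compound 3 the nearer neighbour.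

Compound 4 `Cc1cc(C)nc(SCc2ccc(C(=O)N/N=C/c3c[nH]c4ccccc34)cc2)n1` applies the same exchange to compound 1: 4,6-dimethylpyrimidin-2-yl in place of 1,3-benzothiazol-2-yl on a sulfur. The place is identical, a sulfur whose other neighbour is a saturated chain carbon. Within the data shown here, since an at least 4.5-fold lower number from compound 2 to compound 3 (0.66 log units; beyond the scatter) followed this exchange, compound 4 is expected to read lower than compound 1 as well, although the one precedent starts from a limit and its size on a core that already reads low is uncertain. The expected step is a 2.2-fold lower number from compound 1 to compound 4 (0.34 log units; beyond the scatter). In this assay compound 4 is estimated at 3.5 ug/mL, between 1.2 ug/mL and 10 ug/mL.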

Compound 4, half-maximal inhibitory concentration: 23.2 ug/mL
Beside the measured number, compound 4's estimate is 6.6-fold (0.82 log units) below it; measured number outside the range, above it.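

On the core of compound 1, the exchange of 1,3-benzothiazol-2-yl for 4,6-dimethylpyrimidin-2-yl on a sulfur gave the opposite result in this assay, with a 3.0-fold higher number from compound 1 to compound 4 (0.48 log units; beyond the scatter). The exchange therefore did not carry its direction from one core to the other, and the two steps differ clearly: the same change on two cores in this assay, an at least 4.5-fold lower number (0.66 log units; beyond the scatter) from compound 2 to compound 3 and a 3.0-fold higher number (0.48 log units; beyond the scatter) from compound 1 to compound 4, at least 13-fold (1.13 log units) apart, beyond the scatter of two such steps. This shows that, among these four compounds, the outcome of the exchange depends on the core that carries it, but it does not show which part of the core is responsible, and with compound 2 standing at a limit, the full size of the gap between the two steps remains unknown: the limit of > 80 ug/mL in this assay, at which 1 of the 4 values shown sits.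

With only one pair on each core, the compounds shown leave open whether either direction would recur on a third core, such as one in which the indole-bearing or trimethoxyphenyl-bearing end is replaced by a plain phenyl group. They also leave open how a different group on the same sulfur, such as an unsubstituted pyrimidin-2-yl or a benzoxazol-2-yl, would read on each of the two cores.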